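Carbamate series: fluorine removal on the aryl carbamate

This account rests on a few compounds, and the source may have more. Where it says the series, first, only, none or still open, it means among the compounds named here.

Measured so far:
compound 1 `CCCCOc1ccc(C(CC)NC(=O)Oc2ccc(F)cc2F)cc1` — 21 nM
compound 2 `CCCCOc1ccc(C(CC)NC(=O)Oc2ccc(F)cc2)cc1` — 12 nM
compound 3 `CCCCOc1ccc(CNC(=O)Oc2ccc(F)cc2F)cc1` — 8.7 nM

All three were run in an assay on H4 cells for inhibition of Fatty-acid amide hydrolase 1 (Homo sapiens); on this read-out higher numbers stand for weaker inhibition and lower numbers for stronger inhibition. Compound 1 and compound 2 differ by hydrogen in place of fluoro on an aromatic carbon, and that change gave a 1.8-fold lower number from compound 1 to compound 2 (0.24 log units; within the scatter). Compound 3 differs from compound 1 by hydrogen in place of ethyl on a saturated chain carbon bound to an amide-type nitrogen and an aromatic carbon, with a 2.4-fold lower number from compound 1 to compound 3 (0.38 log units; beyond the scatter). Compound 2 and compound 3 sit within the scatter of each other, so no order between them is claimed.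

Compound 4 `CCCCOc1ccc(CNC(=O)Oc2ccccc2F)cc1` has not yet been measured. It differs from compound 3 by hydrogen in place of fluoro on an aromatic carbon. For the measured compounds named here, this is the same kind of change as the one from compound 1 to compound 2, though not the same: in compound 1 the departing fluoro sits ortho to a large group and meta to a fluoro group, whereas in compound 3 it sits meta to a fluoro group and para to a large group. Going by the values given here, only one such pair, compound 1 to compound 2, is available, and it lay within the scatter.

For compound 4 in this assay the step of a 1.2-fold lower number from compound 3 to compound 4 (0.09 log units; within the scatter) is expected to be small, because the same kind of change gave a 1.8-fold lower number from compound 1 to compound 2 (0.24 log units; within the scatter) in the core of compound 1. Compound 4 is therefore estimated at 7 nM, with 3 nM to 18 nM as the likely range.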

Compound 4, half-maximal inhibitory concentration: 9.2 nM
For compound 4 the middle estimate is 1.3-fold (0.12 log units) below the measured one; measured number inside the range.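

In this assay, taking 2,4-difluorophenyl to 2-fluorophenyl on the shared core of compound 3 gives a 1.1-fold higher number from compound 3 to compound 4 (0.02 log units; within the scatter), so this pair shows no separation between the two carbamates. Set beside the earlier case, the two steps do not differ beyond what repeated measurements would allow: the same change on two cores in this assay, a 1.8-fold lower number (0.24 log units; within the scatter) from compound 1 to compound 2 and a 1.1-fold higher number (0.02 log units; within the scatter) from compound 3 to compound 4, 1.9-fold (0.27 log units) apart, within the scatter of two such steps This shows that hydrogen in place of fluoro on the aromatic carbon has so far given a step within the scatter on both cores, with and without the ethyl group, but it does not establish a rule: there are only two pairs, and the fluoro that leaves does not occupy the same place in them, so they are two related changes rather than one repeated change.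

Still open, from the compounds shown here alone, is how the series reads in this assay with the last fluoro also replaced by hydrogen, or with a chlorine, a nitrile or a methoxy group on the aryl carbamate ring in place of fluoro. Also open, going by these compounds, is whether these small steps would hold on cores carrying a longer chain than butoxy, or an amine on that chain.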